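Replacing a Dimethoxyphenyl Amide with a Cyclopentyl Amide

The compounds below may be only part of what the source reports. "The series", "measured", "known", "first", "only" and "open" are said of these compounds alone.

Of the compounds shown here, three built on one shared core have so far been tested in an assay on HEK293 cells for displacement of a labelled ligand from metabotropic glutamate receptor 5 (Rattus norvegicus); a lower number here means a stronger inhibitor, a higher number a weaker inhibitor. Compound 1 `Cc1ccc(C(=O)Nc2cc(-c3ccccc3)nn2-c2ccccc2)cc1` gives 780 nM, and compound 2 `COc1ccc(C(=O)Nc2cc(-c3ccccc3)nn2-c2ccccc2)cc1` gives 420 nM; the step of a 1.9-fold lower number from compound 1 to compound 2 (0.27 log units; within the scatter) separates them. Compound 3 `COc1cc(OC)cc(C(=O)Nc2cc(-c3ccccc3)nn2-c2ccccc2)c1` gives only a limit, > 10000 nM, which is not a measured number. This places compound 3 at the limit of > 10000 nM in this assay, at which 1 of the 3 values shown sits. Relative to the two numbered compounds it stands far weaker, as the step of an at least 12-fold higher number from compound 1 to compound 3 (1.10 log units; beyond the scatter) and the step of an at least 23-fold higher number from compound 2 to compound 3 (1.37 log units; beyond the scatter) show.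

Compound 4 `O=C(Nc1cc(-c2ccccc2)nn1-c1ccccc1)C1CCCC1` is the next compound to be measured. It differs from compound 3 by cyclopentyl in place of 3,5-dimethoxyphenyl on a carbonyl carbon. The two measured steps that bear on this change are those into compound 3, both of which introduced the 3,5-dimethoxyphenyl and both of which were large losses. Removing that group again in compound 4 is therefore expected to recover a part of what was lost, but cyclopentyl is a group unlike the 4-methylphenyl or 4-methoxyphenyl of compound 1 and compound 2, so the recovery is expected to be partial rather than complete. Compound 4 is estimated at 3000 nM, within a range from 500 nM to 20000 nM. The expected step is an at least 3.3-fold lower number from compound 3 to compound 4 (0.52 log units; beyond the scatter).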

Compound 4, inhibition constant: 11600 nM
Compound 4: middle estimate off by 3.9-fold (0.59 log units), on the low side; low and high end bracket the measured number.
By their numbers in this assay, from the lowest: compounds 2 and 1 (each within the scatter of the next); then compound 4.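

In this assay, putting cyclopentyl on the carbonyl carbon costs as much as the earlier change did, with a 28-fold higher number from compound 2 to compound 4 (1.44 log units; beyond the scatter) and a 15-fold higher number from compound 1 to compound 4 (1.17 log units; beyond the scatter), so a large loss at this position does not depend on the 3,5-dimethoxyphenyl group. Compound 3 gives only a limit, not a number, so the step from it to compound 4 cannot be read, and the two weak compounds cannot be placed in order: the limit of > 10000 nM in this assay, at which 1 of the 4 values shown sits. Across the four compounds, only those carrying 4-methylphenyl and 4-methoxyphenyl give readings well clear of that limit, and compound 3 goes against any idea that an aromatic ring alone on the carbonyl carbon is enough, while compound 4 is a single example of a ring that is not aromatic.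

On these data alone, what remains open is whether the loss in compound 4 comes from losing the aromatic ring or from losing the group at the 4-position of the ring, which an unsubstituted phenyl would help to separate. A 3-methoxyphenyl group would likewise test the 3,5-dimethoxyphenyl result, and cyclohexyl would show whether cyclopentyl speaks for non-aromatic rings more widely.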